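Chain length on the sulfur: trimming toward propyl

The source may hold more compounds than are shown below. What is called first, only, known or untested is meant among the compounds shown, and "the series" means these compounds.

Compound 1 `CCCCSc1n[nH]c(-n2[se]c3ccccc3c2=O)n1`, compound 2 `CCCCCCSc1n[nH]c(-n2[se]c3ccccc3c2=O)n1` and compound 3 `CCCCCSc1n[nH]c(-n2[se]c3ccccc3c2=O)n1` share one core and differ only in the saturated chain on the sulfur. In a functional assay on A549 cells (Homo sapiens) for antiproliferative activity, read by CCK-8 assay, with a stated time of 48 h (on this read-out higher numbers stand for weaker inhibition and lower numbers for stronger inhibition), compound 1 gives 12500 nM, compound 2 gives 20300 nM and compound 3 gives 21100 nM. The step of a 1.6-fold lower number from compound 2 to compound 1 (0.21 log units; within the scatter) is hydrogen in place of ethyl on a saturated chain carbon, four bonds along the chain from a sulfur; compound 2 and compound 3 differ by hydrogen in place of methyl on a saturated chain carbon, five bonds along the chain from a sulfur. Compound 4 `CCCSc1n[nH]c(-n2[se]c3ccccc3c2=O)n1`, not yet measured, is reached from compound 3 by hydrogen in place of ethyl on a saturated chain carbon, three bonds along the chain from a sulfur, the same kind of change as that from compound 2 to compound 1, but placed three bonds rather than four bonds along the chain from the sulfur. Because a 1.6-fold lower number from compound 2 to compound 1 (0.21 log units; within the scatter) lies within the scatter, and the three measured numbers sit close together, a small step is expected: a 1.5-fold lower number from compound 3 to compound 4 (0.18 log units; within the scatter). Compound 4 is estimated at 14000 nM, between 6000 nM and 32000 nM.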

Compound 4, half-maximal inhibitory concentration: 45500 nM
The estimate for compound 4 lay 3.3-fold (0.51 log units) below the measured number; the whole stated range lies below it.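

Removing ethyl does not carry over unchanged from one place on the chain to another in this assay; here it gives a 2.2-fold higher number from compound 3 to compound 4 (0.33 log units; beyond the scatter), set against the earlier step: the same change on two cores in this assay, a 1.6-fold lower number (0.21 log units; within the scatter) from compound 2 to compound 1 and a 2.2-fold higher number (0.33 log units; beyond the scatter) from compound 3 to compound 4, 3.5-fold (0.54 log units) apart, beyond the scatter of two such steps. Removing methyl likewise depends on where it happens, with a 3.6-fold higher number from compound 1 to compound 4 (0.56 log units; beyond the scatter) set against the earlier step: the same change on two cores in this assay, a 1.0-fold higher number (0.02 log units; within the scatter) from compound 2 to compound 3 and a 3.6-fold higher number (0.56 log units; beyond the scatter) from compound 1 to compound 4, 3.5-fold (0.54 log units) apart, beyond the scatter of two such steps. With a 2.2-fold higher number from compound 2 to compound 4 (0.35 log units; beyond the scatter) as well, compound 4 is the weakest of the four, but this shows only that the propyl chain stands apart from the others in this one assay, not why, nor that the same would hold on another core.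

From the compounds shown here alone, how a methyl or ethyl chain on the sulfur would read remains open. So does the effect of a longer chain, or of a chain carrying an amine or a carboxylic acid.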